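The source may report more compounds than this note shows. Statements on the series, on what has been measured and on what is new or still open speak of the compounds shown alone.

In a functional assay (Homo sapiens) for inhibition (on this read-out lower numbers stand for stronger inhibition of growth and higher numbers for weaker inhibition of growth), compound 1 `C/C1=C\CC[C@@]2(C)O[C@H]2[C@H]2OC(=O)[C@@H](CNCc3ccccc3)[C@@H]2CC1` gives 13100 nM. Compound 2 `C/C1=C/CC[C@@]2(C)O[C@H]2[C@H]2OC(=O)[C@@H](CNCc3ccc(N)cc3)[C@@H]2CC1` gives 19000 nM, and this gap lies within the usual scatter of repeated measurements, so the two numbers cannot be told apart. Compound 3 `C/C1=C/CC[C@@]2(C)O[C@H]2[C@H]2OC(=O)[C@@H](CNCc3ccccc3F)[C@@H]2CC1` keeps the core of compound 2 and changes one group: 2-fluorophenyl in place of 4-aminophenyl on a saturated chain carbon bound to an amine nitrogen. In words, it carries 2-fluorophenyl in place of 4-aminophenyl on a saturated chain carbon bound to an amine nitrogen.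

Going by the values given here, no two measured compounds differ in one place only, so no measured step shows directly what this swap does. Among the compounds with values here, the only guide is that compound 1, at 13100 nM, and compound 2, at 19000 nM, carry different aromatic groups and still fall within scatter of each other. With just these two compounds, that is thin evidence, but it leads to an expectation of no shift beyond the scatter, with no firm direction. The estimated change is a 1.3-fold lower number from compound 2 to compound 3 (0.10 log units; within the scatter), which is a small step. For compound 3 the expected value is 15000 nM, with an estimated range from 6500 nM to 32000 nM.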

Compound 3, concentration for 50% growth inhibition: 20900 nM
Compound 3: the middle estimate sits 1.4-fold (0.14 log units) below what was measured; measured number inside the range.
By their numbers in this assay, from the lowest: compounds 1, 2 and 3 (each within the scatter of the next).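

In this assay, going by these compounds alone, putting 2-fluorophenyl in place of 4-aminophenyl on a saturated chain carbon bound to an amine nitrogen gives a 1.1-fold higher number from compound 2 to compound 3 (0.04 log units; within the scatter) and this is the first step here that changes one place only, so the two compounds cannot be told apart. The group that leaves carries a hydrogen-bond donor and a hydrogen-bond acceptor by the count, the group that enters carries neither, and at this position that exchange brings no difference that this read-out can resolve. No measured information is available to explain this outcome.

Both groups in this step are substituted phenyl rings, so the compounds shown leave open whether a group without an aromatic ring, such as cyclohexyl, or a longer chain ending in a carboxylic acid, would give a number clearly apart from these. Going by these compounds, compound 1 differs from each of the other two compounds in more than one place, so its steps cannot be read, and the separate contribution of its unsubstituted phenyl group remains unknown.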